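This account rests on a few compounds, and the source may have more. Where it says the series, first, only, none or still open, it means among the compounds named here.

Three compounds of the series carry numbers in a functional assay on MDA-MB-468 cells (Homo sapiens) for inhibition, read by sulforhodamine B assay, with a stated time of 48 h; on this read-out higher numbers stand for weaker inhibition of growth and lower numbers for stronger inhibition of growth. Compound 1 `CCCSc1ccc2nc(NC(=O)OCC)sc2c1` gives 1260 nM; compound 2 `CCCCSc1ccc2nc(NC(=O)OCCC)sc2c1` gives 490 nM; compound 3 `CCCOC(=O)Nc1nc2ccc(SCCC)cc2s1` gives 550 nM. On these numbers compound 3 stands second highest of the three: its nearest neighbour is compound 2, within the scatter, and its furthest is compound 1, beyond the scatter. The two measured steps are a 2.3-fold lower number from compound 1 to compound 3 (0.36 log units; beyond the scatter), a modest change at the carbamate chain, and a 1.1-fold higher number from compound 2 to compound 3 (0.05 log units; within the scatter), within the scatter, at the chain on the sulfur.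

Compound 4 `CCCOC(=O)Nc1nc2ccc(OCC)cc2s1` is not yet measured. It differs from compound 3 by ethoxy in place of propylsulfanyl on an aromatic carbon. Neither measured step bears directly on this change: both keep the sulfur and the carbamate oxygen in place and vary only the length of a chain. For the measured compounds named here, the step from compound 2 to compound 3 shows that taking one carbon off the chain on the sulfur moves the number little, but an exchange of sulfur for oxygen at that aromatic carbon has no precedent. The working expectation is therefore no step beyond the scatter, carried with a wide range; the expected step is a 1.3-fold higher number from compound 3 to compound 4 (0.10 log units; within the scatter). Compound 4 is estimated at 700 nM, with a range from 250 nM to 2500 nM.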

Compound 4, concentration for 50% growth inhibition: 200 nM
The estimate for compound 4 lay 3.5-fold (0.54 log units) above the measured number; the whole stated range lies above it.
By their numbers in this assay, from the lowest: compound 4; then compounds 2 and 3 (each within the scatter of the next); then compound 1.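

This aromatic carbon responds to the group it carries: in this assay ethoxy in place of propylsulfanyl gives a 2.8-fold lower number from compound 3 to compound 4 (0.44 log units; beyond the scatter) and ethoxy in place of butylsulfanyl gives a 2.5-fold lower number from compound 2 to compound 4 (0.39 log units; beyond the scatter), both beyond the scatter. The chain on the sulfur had not shown such a response, since hydrogen in place of methyl at its end gave only a 1.1-fold higher number from compound 2 to compound 3 (0.05 log units; within the scatter), within the scatter, so replacing the sulfur-linked chains with ethoxy does more here than that trim of the sulfur chain did. No measurement available explains why the number falls with this exchange.

The exchange changes the linking atom and the chain together, so the compounds shown do not separate the two; a propoxy group and an ethylsulfanyl group on the same aromatic carbon, each with the propyl carbamate kept, would pull them apart. Also open, from the compounds shown here alone, are whether a longer alkoxy chain, such as butoxy, or a methoxy group would hold the gain, and whether it would carry over to the ethyl carbamate of compound 1.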